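A few compounds are considered here, and "the series" means these few. Any claim that something is new, unique, unknown or untested is made for them only; others in the source may bear on it.

Of the compounds shown here, three have been measured in a physicochemical assay for lipophilicity, in phosphate buffer, measured as octanol-water partition; on this read-out lower numbers stand for lower lipophilicity and higher numbers for higher lipophilicity. Compound 1 `O=[N+]([O-])c1ccc(/C=N/NC(=S)Nc2nc3ccc(Cl)cc3s2)cc1` gives 4.68, compound 2 `S=C(N/N=C/c1ccccc1)Nc1nc2ccc(Cl)cc2s1` gives 4.86, and compound 3 `S=C(N/N=C/c1ccc(Cl)cc1)Nc1nc2ccc(Cl)cc2s1` gives 5.52. Compound 3 stands highest of the three: the nearest is compound 2, with a number 0.66 log units higher from compound 2 to compound 3 (beyond the scatter), and the furthest is compound 1, with a number 0.84 log units higher from compound 1 to compound 3 (beyond the scatter). Compound 1 and compound 2 lie within the scatter of one another, as shown by a number 0.18 log units higher from compound 1 to compound 2 (within the scatter).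

The step now followed leads from compound 3 to compound 4 `CN(C)c1ccc(/C=N/NC(=S)Nc2nc3ccc(Cl)cc3s2)cc1`. dimethylamino in place of chloro on an aromatic carbon Two measured steps bear on it, since both put chloro onto this aromatic carbon and both raised this assay by a modest amount: from compound 2 to compound 3 and from compound 1 to compound 3. Taking chloro away again is therefore expected to lower this assay, and dimethylamino is not expected to restore what chloro gave. Compound 4 is expected to land near compound 2, with a number 0.52 log units lower from compound 3 to compound 4 (beyond the scatter), so that compound 4 is estimated at 5, within a range from 4.5 to 5.5.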

Compound 4, partition coefficient: 5.24
Beside the measured number, compound 4's estimate is 0.24 log units below it; the range from low to high includes it.
By their numbers in this assay, from the lowest: compounds 1 and 2 (each within the scatter of the next); then compounds 4 and 3 (each within the scatter of the next).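

At this aromatic carbon, para to a large group, this assay does not separate dimethylamino from chloro, with a number 0.28 log units lower from compound 3 to compound 4 (within the scatter), even though three heavy atoms enter where one chlorine leaves. Dimethylamino does stand apart from the other two groups, with a number 0.38 log units higher from compound 2 to compound 4 (beyond the scatter) and a number 0.56 log units higher from compound 1 to compound 4 (beyond the scatter), so the four compounds fall into two pairs: hydrogen and nitro in compounds 1 and 2, chloro and dimethylamino in compounds 3 and 4. Nothing measured here gives a reason for this grouping.

As far as these compounds go, it remains open where other groups at this position would fall, such as a carboxylic acid, a primary amine or a longer alkyl chain, and whether they would join either pair. From the compounds shown here alone, it is also open whether the two pairs would persist if the chloro on the shared core were replaced by another group.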